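A carbonyl and chlorine enter the side chain

The source may report more compounds than this note shows. Statements on the series, on what has been measured and on what is new or still open speak of the compounds shown alone.

In an ADME assay on MT4 cells (Homo sapiens) for cytotoxicity, read by MTT assay (on this read-out lower numbers stand for higher toxicity in this test and higher numbers for lower toxicity in this test), compound 2 (`O=c1cc(Cc2c(F)cccc2F)nc(SCCc2ccccc2)[nH]1`) gives > 70000 nM, which is a limit and not a number. Compound 1 (`O=c1cc(Cc2c(F)cccc2F)nc(Sc2ccccc2)[nH]1`) also gives only a limit, > 76000 nM. Compound 2 therefore has no exact position on this scale, and the comparison of these two compounds yields a step that the two limits leave unreadable from compound 1 to compound 2. Compound 3 (`O=c1cc(Cc2c(F)cccc2F)nc(SCCCc2ccccc2)[nH]1`) gives an actual number, 32000 nM. Within the data shown here, the only readable step is an at least 2.1-fold lower number from compound 2 to compound 3 (0.33 log units; beyond the scatter).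

Compound 4 (`O=C(CSc1nc(Cc2c(F)cccc2F)cc(=O)[nH]1)c1ccc(Cl)cc1`) alters the side chain of compound 2 in a different way: (4-chlorophenyl)carbonyl in place of benzyl on a saturated chain carbon bound to a sulfur. Among the measured compounds shown here, no measured compound carries a carbonyl or a chlorine on this chain, so the evidence is thin. The closest guide is compound 3, a second change to the same benzyl end of the chain, with an at least 2.1-fold lower number from compound 2 to compound 3 (0.33 log units; beyond the scatter). A modest move toward a lower number is therefore expected, and the expected step is an at least 2.0-fold lower number from compound 2 to compound 4 (0.30 log units; that floor lies within the scatter). For compound 4 the estimated value is 35000 nM, with an expected range from 12000 nM to 90000 nM.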

Compound 4, half-maximal cytotoxic concentration: > 61000 nM
Compound 4: only a limit was reported; the forecaster's own chance of this, stated with the estimate: 35%; middle value at least 1.7-fold (0.24 log units) away from the limit.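

The (4-chlorophenyl)carbonyl group on the saturated chain carbon bound to a sulfur keeps compound 4 among the compounds reported only as limits in this assay: the limit of > 61000 nM in this assay, at which 1 of the 4 values shown sits. The step from compound 2 to compound 4 cannot be read, so this change has no measurable size here. Among these compounds, the one readable comparison is with the only actual number, an at least 1.9-fold higher number from compound 3 to compound 4 (0.28 log units; that floor lies within the scatter), so the result does not show the lower number seen with compound 3, although this comparison does not clear the usual scatter.

Going by these compounds, the carbonyl and the chlorine enter together, so their separate contributions remain open, and compound 4 has no exact position on this scale. Also open, on these data alone, is how an amine or a carboxylic acid on this chain would read in this assay.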